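Taking one methoxy away from compound 3

The compounds below may be only part of what the source reports. "The series", "measured", "known", "first", "only" and "open" are said of these compounds alone.

In an ADME assay on L929 cells (Mus musculus) for cytotoxicity, read by resazurin assay, with a stated time of 72 h (on this read-out higher numbers stand for weaker inhibition and lower numbers for stronger inhibition), compound 1 `O=C(/C=C/c1ccc2c(c1)B(O)OC2)c1ccccn1` gives only a limit, > 10 ug/mL. Compound 2 `COc1ccccc1C(=O)/C=C/c1ccc2c(c1)B(O)OC2` gives 6.35 ug/mL and compound 3 `COc1ccc(C(=O)/C=C/c2ccc3c(c2)B(O)OC3)c(OC)c1` gives 7.87 ug/mL, so compound 3 stands level with compound 2 within the scatter. Compound 4 `COc1ccc(C(=O)/C=C/c2ccc3c(c2)B(O)OC3)cc1` differs from compound 3 by one swap, hydrogen in place of methoxy on an aromatic carbon. Going by the values given here, the only measured step of this kind runs the other way and at a different carbon: a 1.2-fold higher number from compound 2 to compound 3 (0.09 log units; within the scatter). That small step gives no reason to expect a large change, so the expected result is a 1.0-fold lower number from compound 3 to compound 4 (0.02 log units; within the scatter), with nothing beyond the scatter. Compound 4 is estimated at 7.5 ug/mL, with an expected range of 4 ug/mL to 14 ug/mL.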

Compound 4, half-maximal inhibitory concentration: > 10 ug/mL
Compound 4: no number, only a limit (the forecaster's own chance of this, stated with the estimate: 20%); middle value at least 1.3-fold (0.12 log units) away from the limit.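

At the aromatic carbon ortho to a large group and meta to a methoxy group, hydrogen in place of methoxy gives an at least 1.2-fold higher number from compound 3 to compound 4 (0.10 log units; that floor lies within the scatter) in this assay. Compound 4 has only a limit, so this step is a floor rather than a measured size, and the floor alone does not show that removing this methoxy matters. The true size of the step stays hidden behind that limit: the limit of > 10 ug/mL in this assay, at which 2 of the 4 values shown sit.

On these data alone, how far compound 4 lies past its limit remains open. So does whether an amine or a carboxylic acid at this carbon would give a number rather than a limit.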